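A few compounds are considered here, and "the series" means these few. Any claim that something is new, unique, unknown or untested is made for them only; others in the source may bear on it.

Compound 1 `CC1=C(C(=O)CC(C)C)C(c2cccs2)NC(=O)N1`: 43%. Compound 2 `CC1=C(c2ncc(C)o2)C(c2cccs2)NC(=O)N1`: 45%.

Both were tested in an assay on membranes from HEK293 cells for displacement of a labelled ligand from adenosine receptor A2b (Homo sapiens), read by scintillation counting, with a stated time of 30 min, tested at 1 uM; a higher number here means more inhibition at the concentration tested (going by the name of the read-out), a lower number less inhibition. Compound 1 stands lowest of the two numbers, with compound 2 nearest, and the step of a number 2 percentage points higher from compound 1 to compound 2 (within the scatter) lies within the scatter. Compound 3 `CC1=C(C(=O)OC2CCCC2)C(c2cccs2)NC(=O)N1` has not been measured; it differs from compound 1 by cyclopentyloxy in place of isobutyl on a carbonyl carbon. Among the measured compounds shown here, the one measured step altered the group on the double-bonded ring carbon rather than on the carbonyl carbon, so it bears only loosely on this change, and it was small. No step beyond the scatter is therefore expected, giving a number 2 percentage points higher from compound 1 to compound 3 (within the scatter). Compound 3 is estimated at 45%, between 25% and 65%.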

Compound 3, a percentage reported as inhibition, at one concentration (the size of the read-out at that concentration, not a potency): 1%
Beside the measured number, compound 3's estimate is 44 percentage points above it; the whole stated range lies above it.
By their numbers in this assay, from the lowest: compound 3; then compounds 1 and 2 (each within the scatter of the next).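

Cyclopentyloxy in place of isobutyl on a carbonyl carbon gives a number 42 percentage points lower from compound 1 to compound 3 (beyond the scatter), so the group held by this carbonyl carbon can strongly change the reading, even though the one earlier step was small. The change brings in a ring and an oxygen together, and the pair of compounds cannot separate the two. Nothing available explains the drop.

As far as these compounds go, it stays open whether the ring or the oxygen goes with the lower number. Cyclopentyl or isobutoxy on the same carbonyl carbon would tell these apart.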